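This account rests on a few compounds, and the source may have more. Where it says the series, first, only, none or still open, it means among the compounds named here.

Among the compounds with values here, compound 2, with the structure `CC(C(=O)N1CCCc2ccccc21)N1CCN(S(=O)(=O)c2ccc(C(C)(C)C)cc2)CC1`, is one of two compounds measured in an ADME assay on HepG2 cells (Homo sapiens) for inhibition, with a stated time of 48 h; on this read-out lower numbers stand for an effect already at smaller amounts and higher numbers for an effect only at larger amounts of compound. In this assay compound 2 gives > 40000 nM, which is a limit of the assay rather than a number. Its closest neighbour, compound 1 with the structure `CC(C(=O)N1CCOCC1)N1CCN(S(=O)(=O)c2ccc(C(C)(C)C)cc2)CC1`, stands in the same place. In this assay compound 1 gives > 40000 nM, again a limit. The step that the two limits leave unreadable from compound 1 to compound 2 therefore cannot be read, and the limit of > 40000 nM in this assay, at which 2 of the 2 values shown sit, describes all that the two values show. Compound 3, with the structure `CC(C(=O)N1Cc2ccccc2C1)N1CCN(S(=O)(=O)c2ccc(C(C)(C)C)cc2)CC1`, carries the change (a group of 9 heavy atoms (8 carbon, 1 nitrogen; one five-membered non-aromatic ring with 1 hetero atom, one six-membered aromatic ring of carbon only) in place of a group of 10 heavy atoms (9 carbon, 1 nitrogen; one six-membered non-aromatic ring with 1 hetero atom, one six-membered aromatic ring of carbon only), on a carbonyl carbon), a group of 9 heavy atoms in place of a group of 10 heavy atoms on the carbonyl carbon whose other neighbour is a saturated chain carbon. Within the data shown here, no measured step bears on this change in a readable way, so no step beyond the scatter is expected, and the estimated step that the limit leaves unreadable from compound 2 to compound 3 is accordingly set near zero. Compound 3 is expected to give about 60000 nM in this assay, within the range 20000 nM to 160000 nM, most likely again reported only as a limit.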

Compound 3, half-maximal effective concentration: > 40000 nM
Compound 3: no number, only a limit (the forecaster's own chance of this, stated with the estimate: 85%); the middle value does not contradict the limit.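

Compound 3 joins compound 1 and compound 2 as a limit of this assay rather than a number, so the steps from compound 3 to either of them cannot be read: the limit of > 40000 nM in this assay, at which 3 of the 3 values shown sit.

The compounds shown leave open whether exchanging the group on the carbonyl carbon changes the read-out in this assay at all.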